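The compounds below may be only part of what the source reports. "The series", "measured", "known", "first", "only" and "open" are said of these compounds alone.

Measured in an ADME assay on HepG2 cells (Homo sapiens) for cytotoxicity, in the presence of a further agent that is not named here; on this read-out higher numbers stand for weaker inhibition and lower numbers for stronger inhibition:
- Compound 1 `Cn1c(Cc2ccccc2C(F)(F)F)nc(C(=O)NCc2cccnc2)c(O)c1=O`: > 100000 nM
- Compound 2 `COc1c(C(=O)NCc2ccccc2)nc(Cc2ccccc2C(F)(F)F)n(C)c1=O`: > 100000 nM

Compound 1 stands at > 100000 nM, and this is a limit of the assay, not a number. Compound 2 gives > 100000 nM, which is likewise a limit. Among the compounds with values here, the whole record therefore amounts to the limit of > 100000 nM in this assay, at which 2 of the 2 values shown sit, and no measured pair yet shows a step of any size.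

Compound 3 `Cn1c(Cc2ccccc2C(F)(F)F)nc(C(=O)NCc2ccccn2)c(O)c1=O` keeps the core of compound 1 and has the same atoms, joined differently: pyridin-2-yl in place of pyridin-3-yl on a saturated chain carbon bound to an amide-type nitrogen. Pyridin-2-yl takes the place of pyridin-3-yl on a saturated chain carbon bound to an amide-type nitrogen.

The expectation rests on compound 1, with its limit of > 100000 nM, and on how small this exchange is. In this assay, no change beyond the usual scatter is expected. The expected step is a number no higher from compound 1 to compound 3 (the limit leaves the size open). For compound 3 the estimate is 100000 nM, with an expected range from 50000 nM to 200000 nM, and the assay is expected most likely to report only a limit again.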

Compound 3, half-maximal inhibitory concentration: > 100000 nM
Compound 3 gave a limit, no number; the forecaster's own chance of this, stated with the estimate: 85%; the middle value lies on the limit itself.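

No step can be read from compound 1 to compound 3, since each gives only a limit, not a number, in this assay and the record stays as follows: the limit of > 100000 nM in this assay, at which 3 of the 3 values shown sit. The compounds shown leave open whether pyridin-2-yl and pyridin-3-yl differ at all on this read-out, and at what concentration any of them would inhibit.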